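Thiophenylsulfanyl for thiazolidinedione on the shared core

A few compounds are considered here, and "the series" means these few. Any claim that something is new, unique, unknown or untested is made for them only; others in the source may bear on it.

Compound 1 `CN(CCC#N)C[C@H]1CN(c2ccc(-n3cc(-c4ccccn4)cn3)c(F)c2)C(=O)O1` 1.9
Compound 2 `CCN1CCN(C[C@H]2CN(c3ccc(-n4cc(-c5ccccn5)cn4)c(F)c3)C(=O)O2)CC1` 2.19
Compound 3 `O=C1CSC(=O)N1C[C@H]1CN(c2ccc(-n3cc(-c4ccccn4)cn3)c(F)c2)C(=O)O1` 2.18

Three compounds share one core and differ only in the group on a saturated chain carbon bound to a saturated ring carbon. In a physicochemical assay for lipophilicity, read by HPLC, measured as octanol-water partition (on this read-out higher numbers stand for higher lipophilicity and lower numbers for lower lipophilicity), compound 1 gives 1.9, compound 2 gives 2.19 and compound 3 gives 2.18. Compound 3 stands second highest of the three, nearest to compound 2 and furthest from compound 1, yet all three lie within the scatter of one another: a number 0.29 log units higher from compound 1 to compound 2 (within the scatter), a number 0.28 log units higher from compound 1 to compound 3 (within the scatter) and a number 0.01 log units lower from compound 2 to compound 3 (within the scatter).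

Compound 4 `O=C1O[C@@H](CSc2cccs2)CN1c1ccc(-n2cc(-c3ccccn3)cn2)c(F)c1` is not yet measured. Its change from compound 3 is (thiophen-2-yl)sulfanyl in place of 2,4-dioxo-1,3-thiazolidin-3-yl on a saturated chain carbon bound to a saturated ring carbon. Among the measured compounds shown here, the steps that bear on it are those that set the 2,4-dioxo-1,3-thiazolidin-3-yl group in place of another, namely a number 0.28 log units higher from compound 1 to compound 3 (within the scatter) and a number 0.01 log units lower from compound 2 to compound 3 (within the scatter), and neither went beyond the scatter. For the measured compounds named here, no measured step covers the entering (thiophen-2-yl)sulfanyl group, so the expectation rests on the counted change alone. Compound 4 is expected to give 3.3 in this assay, between 2.6 and 4. That estimate means a step of a number 1.12 log units higher from compound 3 to compound 4 (beyond the scatter), expected to lie beyond the scatter and upward.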

Compound 4, partition coefficient: 4.29
For compound 4 the middle estimate is 0.99 log units below the measured one; measured number outside the range, above it.
By their numbers in this assay, from the lowest: compounds 1, 3 and 2 (each within the scatter of the next); then compound 4.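

Until now, the position on a saturated chain carbon bound to a saturated ring carbon had shown no spread in this assay. The three earlier groups all lay within the scatter of one another. (Thiophen-2-yl)sulfanyl breaks that flat picture, giving a number 2.11 log units higher from compound 3 to compound 4 (beyond the scatter), along with a number 2.10 log units higher from compound 2 to compound 4 (beyond the scatter) and a number 2.39 log units higher from compound 1 to compound 4 (beyond the scatter), so the same position can carry a large step. The exchange from 2,4-dioxo-1,3-thiazolidin-3-yl changes the heavy-atom count little, but a five-membered non-aromatic ring gives way to a five-membered aromatic one, and nitrogen and oxygen leave the group, and nothing measured here ties the step to any one of these differences.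

The compounds shown leave open how the step divides between the sulfanyl link and the thiophen-2-yl part, as the two enter together in compound 4 alone. A methylsulfanyl group would test the link without the aromatic ring, and a thiophen-2-yloxy group would test the ring with oxygen as the link in place of sulfur.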